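Swapping a fluorophenyl for an aminophenyl on a shared core

This account rests on a few compounds, and the source may have more. Where it says the series, first, only, none or still open, it means among the compounds named here.

Compound 1 `Fc1ccc(Nc2nc(-c3cccc(F)c3)nc3ccc(F)cc23)cc1`: in a functional assay on MCF7 cells (Homo sapiens) for cytotoxicity, read by MTT assay, with a stated time of 48 h (on this read-out lower numbers stand for stronger inhibition and higher numbers for weaker inhibition), compound 1 gives > 50000 nM, a limit of the assay rather than a number.
Compound 2 `Oc1ccc(Nc2nc(-c3cccc(F)c3)nc3ccc(F)cc23)cc1`: in this assay compound 2 gives > 50000 nM, again a limit.
Compound 3 `Nc1ccc(Nc2nc(-c3cccc(F)c3)nc3ccc(F)cc23)cc1`: in this assay compound 3 gives > 50000 nM, also a limit.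

Compound 1 therefore stands only at a limit, and so do the two compounds shown beside it. The steps a step that the two limits leave unreadable from compound 1 to compound 2, a step that the two limits leave unreadable from compound 1 to compound 3 and a step that the two limits leave unreadable from compound 2 to compound 3 cannot be sized, since every value sits at the same edge of the assay, as shown by the limit of > 50000 nM in this assay, at which 3 of the 3 values shown sit. Compound 4 `Nc1ccccc1Nc1nc(-c2cccc(F)c2)nc2ccc(F)cc12` is not yet measured. It differs from compound 1 as follows: 2-aminophenyl in place of 4-fluorophenyl on a nitrogen on an aromatic ring. For the measured compounds named here, none of the measured steps puts a readable number on what a change on this nitrogen does, so the expectation rests only on the fact that all three measured compounds sit at the limit. Compound 4 is expected to give 60000 nM, with a range from 20000 nM to 200000 nM, most likely again reported only as a limit. The step that the limit leaves unreadable from compound 1 to compound 4 is thus expected to be no more than scatter.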

Compound 4, half-maximal inhibitory concentration: > 50000 nM
Compound 4: no number, only a limit (the forecaster's own chance of this, stated with the estimate: 80%); the middle value lies beyond the limit too.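

For the compounds shown here, no step from compound 1, compound 2 or compound 3 to compound 4 can be read, since all four values sit at the same edge: the limit of > 50000 nM in this assay, at which 4 of the 4 values shown sit. On these data alone, what stays open is how far apart these four compounds really lie, as none of them has yet given a number in this assay.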